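The compounds below may be only part of what the source reports. "The series", "measured", "known", "first", "only" and "open" are said of these compounds alone.

Measured so far:
compound 1, `Cc1ccc(OCC(=O)N2CCN(c3ccc(C(F)(F)F)cc3[C@@H](N)CC(C)C)CC2)cc1`: 4400 nM
compound 2, `CC(C)C[C@H](N)c1cc(C(F)(F)F)ccc1N1CCN(C(=O)COc2ccc([N+](=O)[O-])cc2)CC1`: 3100 nM
compound 3, `COc1cc(Cl)ccc1CC(C)C(=O)N1CCN(c2ccc(Cl)cc2[C@@H](N)CC(C)C)CC1`: 9.1 nM

In an assay on HEK293 cells for displacement of a labelled ligand from Melanocortin receptor 4 (Homo sapiens) (a lower number here means a stronger inhibitor, a higher number a weaker inhibitor), compound 1 stands highest of the three numbers; compound 2 lies within the scatter of it, and compound 3 sits far lower. Among the compounds with values here, the only measured step, a 1.4-fold lower number from compound 1 to compound 2 (0.15 log units; within the scatter), changes a substituent on the far aromatic ring and is within the scatter, so it says little about the move to compound 4, `CCOc1cccc(CC(C)C(=O)N2CCN(c3ccc(C(F)(F)F)cc3[C@@H](N)CC(C)C)CC2)c1`, in which (1-(3-ethoxybenzyl)ethyl in place of (4-methylphenoxy)methyl on a carbonyl carbon). Within the data shown here, no measured pair isolates this change. Compound 3 shares the branched acyl side with compound 4 but differs from it in two places; in this assay compound 3 gives 9.1 nM, and compound 1 gives 4400 nM; these two values alone suggest the new acyl side may carry a large gain. Compound 4 is therefore expected at 50 nM, between 10 nM and 300 nM, a step of an 88-fold lower number from compound 1 to compound 4 (1.94 log units; beyond the scatter).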

Compound 4, inhibition constant: 2200 nM
Compound 4: the middle estimate sits 44-fold (1.64 log units) below what was measured; the whole stated range lies below it.
By their numbers in this assay, from the lowest: compound 3; then compounds 4, 2 and 1 (each within the scatter of the next).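

On a carbonyl carbon whose other neighbours are an amide-type nitrogen in a ring, 1-(3-ethoxybenzyl)ethyl in place of (4-methylphenoxy)methyl gives a 2.0-fold lower number from compound 1 to compound 4 (0.30 log units; within the scatter) in this assay, and in place of (4-nitrophenoxy)methyl it gives a 1.4-fold lower number from compound 2 to compound 4 (0.15 log units; within the scatter). With the core of compound 1 held fixed, this read-out therefore does not tell the new group apart from either phenoxy group. No evidence bearing on this result is available. The compounds shown leave open which of its two differences from compound 4 goes with the value of compound 3 at 9.1 nM. They also leave open how a chain ending in an amine or a carboxylic acid would read at this place.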